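This account rests on a few compounds, and the source may have more. Where it says the series, first, only, none or still open, it means among the compounds named here.

Two close relatives share one core. In a functional assay on A549 cells (Homo sapiens) for antiproliferative activity, read by MTT assay, with a stated time of 24 h (on this read-out higher numbers stand for weaker inhibition and lower numbers for stronger inhibition), compound 1 `Clc1ccc(C2CC(c3ccccc3)=NN2c2ccc(-c3ccccc3)nn2)cc1` gives 100000 nM and compound 2 `Clc1ccc(C2=NN(c3ccc(-c4ccccc4)nn3)C(c3ccccc3)C2)cc1` gives 96700 nM; compound 2 has the lowest of the two numbers, yet its gap to compound 1 lies within the scatter, so the two are indistinguishable here. Compound 3 `Clc1ccc(C2=NN(c3ccc(-c4ccccc4)nn3)C(c3ccc(Cl)cc3)C2)cc1` differs from compound 2 by chloro in place of hydrogen on an aromatic carbon. Within the data shown here, with no measured step of this kind at hand, the expected change from compound 2 to compound 3 in this assay is a 1.1-fold lower number from compound 2 to compound 3 (0.03 log units; within the scatter), nothing beyond the scatter. Compound 3 is therefore estimated at 90000 nM, with a range from 40000 nM to 160000 nM.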

Compound 3, half-maximal inhibitory concentration: > 100000 nM
Compound 3: no number, only a limit; the forecaster's own chance of this, stated with the estimate: 25%; middle value at least 1.1-fold (0.04 log units) from the limit.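

In this assay compound 3 gives > 100000 nM, which is a limit of the assay and not a number. At this position, para to a large group, the change from phenyl to 4-chlorophenyl gives an at least 1.0-fold higher number from compound 2 to compound 3 (0.01 log units; that floor lies within the scatter), so chloro here brings no stronger inhibition, and the step that gives a number no lower from compound 1 to compound 3 (the limit leaves the size open) cannot be read for size. How much weaker compound 3 may be also stays unknown, as its value sits at the edge of what is reported: the limit of > 100000 nM in this assay, at which 1 of the 3 values shown sits.

From the compounds shown here alone, whether an amine or a methoxy group at this place would bring the number down remains open.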